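The compounds below may be only part of what the source reports. "The series", "measured", "known", "first", "only" and "open" are said of these compounds alone.

Working notes on the series

Compound 3 `COc1ccccc1C(Oc1cc(OCc2ccsc2)ccc1C#N)C(=O)O` stands at the highest number of the three measured in an assay on A10 cells for antagonist activity at Endothelin-1 receptor (Rattus norvegicus); on this read-out lower numbers stand for stronger inhibition and higher numbers for weaker inhibition: compound 3 gives 529 nM. Compound 1 `N#Cc1ccc(OCc2ccsc2)cc1OC(C(=O)O)c1ccccc1Cl` gives 17 nM in this assay, and compound 2 `N#Cc1ccc(OCc2ccsc2)cc1OC(C(=O)O)c1ccccc1Br` gives 51 nM. Both steps into compound 3 are large: a 31-fold higher number from compound 1 to compound 3 (1.49 log units; beyond the scatter) and a 10-fold higher number from compound 2 to compound 3 (1.02 log units; beyond the scatter). The step between the two halogen analogues is smaller, a 3.0-fold higher number from compound 1 to compound 2 (0.48 log units; beyond the scatter).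

Compound 4 `N#Cc1ccc(OCc2ccsc2)cc1OC(C(=O)O)c1ccccc1C(F)(F)F` differs from compound 3 by trifluoromethyl in place of methoxy on an aromatic carbon. Among the compounds with values here, no measured step involves trifluoromethyl, so no direct precedent exists. What bears on the change is that the only two measured departures at this carbon, a 31-fold higher number from compound 1 to compound 3 (1.49 log units; beyond the scatter) and a 10-fold higher number from compound 2 to compound 3 (1.02 log units; beyond the scatter), both show methoxy at the high end of the numbers by a wide margin, with chloro and bromo within a modest step of one another. On that basis leaving methoxy for trifluoromethyl is expected to give a large step downward in this assay, though whether compound 4 lands near compound 1 or compound 2 or somewhat short of them cannot be read from three points.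

The step to compound 4 is expected as a 7.6-fold lower number from compound 3 to compound 4 (0.88 log units; beyond the scatter). Compound 4 is therefore estimated at 70 nM, with a range from 15 nM to 300 nM.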

Compound 4, half-maximal inhibitory concentration: 53 nM
The estimate for compound 4 lay 1.3-fold (0.12 log units) above the measured number; low and high end bracket the measured number.
By their numbers in this assay, from the lowest: compound 1; then compounds 2 and 4 (each within the scatter of the next); then compound 3.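

In this assay, the step of a 10-fold lower number from compound 3 to compound 4 (1.00 log units; beyond the scatter) shows that a high number is not a general result of leaving chloro or bromo at this aromatic carbon: among the four groups, only methoxy stands well apart. Trifluoromethyl and bromo cannot be told apart, with a 1.0-fold higher number from compound 2 to compound 4 (0.02 log units; within the scatter), whereas chloro keeps the lowest number, with a 3.1-fold higher number from compound 1 to compound 4 (0.49 log units; beyond the scatter), and compound 1 is the only compound whose steps to all the others are beyond the scatter. The compounds come with no information that could explain why methoxy stands apart from the other three groups.

As far as these compounds go, whether fluoro or methyl at this carbon would reach the number of compound 1, and whether ethoxy or hydroxy would fall with methoxy at the high end, remains open. From the compounds shown here alone, it is also open whether the wide gap between methoxy and the other three groups would persist if an amide replaced the nitrile on the shared core.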